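This account rests on a few compounds, and the source may have more. Where it says the series, first, only, none or still open, it means among the compounds named here.

Measured so far:
compound 1, `CCCCNc1nc(N)nc(C)c1CCCN1CCN(C)CC1`, 179 nM
compound 2, `CCCCNc1nc(N)nc(C)c1CCCN1Cc2ccccc2C1`, 29 nM
compound 3, `CCCCNc1nc(N)nc(C)c1CCCn1ccc2ccccc21`, 1100 nM

In an assay on HEK293 cells for agonist activity at Toll-like receptor 8 (Homo sapiens), read by spectrophotometry (a lower number here means that less compound is needed, a higher number that more compound is needed for the effect), compound 1 stands second highest of the three numbers: compound 2 gives a lower number and compound 3 a higher one, and both gaps lie beyond the scatter of the measurement.

Compound 4, `CCCCNc1nc(N)nc(C)c1CCCCCc1ccccc1`, has not been measured. It differs from compound 1 in one place: phenethyl in place of 4-methylpiperazin-1-yl on a saturated chain carbon, three bonds along the chain from an aromatic carbon. The piperazine ring with its two nitrogen atoms gives way to an all-carbon aromatic ring on the same chain.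

Within the data shown here, no measured pair shows this exact change. Among the three measured compounds, compound 3 gives the highest number, 1100 nM, and compound 2 the lowest, 29 nM, so the numbers spread widely across the groups at this chain position. For compound 4 the step of a 4.5-fold higher number from compound 1 to compound 4 (0.65 log units; beyond the scatter) is expected to run upward and beyond the scatter. Compound 4 is therefore estimated at 800 nM, within a range from 250 nM to 2500 nM.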

Compound 4, half-maximal effective concentration: 830 nM
For compound 4 the middle estimate is 1.0-fold (0.02 log units) below the measured one; the measured number falls inside the stated range.
By their numbers in this assay, from the lowest: compound 2; then compound 1; then compounds 4 and 3 (each within the scatter of the next).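

In this assay, swapping 4-methylpiperazin-1-yl for phenethyl at this chain position gives a 4.6-fold higher number from compound 1 to compound 4 (0.67 log units; beyond the scatter), so this all-carbon aromatic group goes with a need for more compound than the ring with its two nitrogen atoms. Compound 4 at 830 nM and compound 3 at 1100 nM lie within the scatter of each other, so these two different groups on the chain give numbers that cannot be told apart. Nothing measured here explains why the number rises with this change.

The change removes the nitrogen atoms and brings in an aromatic ring at once, so the two cannot be separated. A cyclohexyl group, which is a saturated all-carbon ring, or a piperidine ring, which has a single nitrogen atom, on the same chain would help to pull these apart.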